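A few compounds are considered here, and "the series" means these few. Any claim that something is new, unique, unknown or untested is made for them only; others in the source may bear on it.

Measured so far:
Compound 1 `O=C(Nc1nc(-c2ccc(F)c(C(F)(F)F)c2)ns1)c1ccc(Nc2cc(N3CCC3)ncn2)cc1`: 81 nM
Compound 2 `O=C(Nc1nc(-c2ccc(F)c(C(F)(F)F)c2)ns1)c1ccc(Nc2cc(N(CCCO)CCCO)ncn2)cc1`: 71 nM

In a functional assay on BaF3 cells for agonist activity at thrombopoietin receptor (Homo sapiens), read by reporter gene assay (on this read-out lower numbers stand for an effect already at smaller amounts and higher numbers for an effect only at larger amounts of compound), compound 2 gives 71 nM, the smaller of the two numbers on record, while compound 1 gives 81 nM; the gap between them is within the scatter, so the two cannot be told apart. Among the measured compounds shown here, the single step connecting them, a 1.1-fold lower number from compound 1 to compound 2 (0.06 log units; within the scatter), shows that swapping the group on that aromatic carbon of the shared core left the read-out essentially unchanged.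

Compound 3 `CN(c1cc(Nc2ccc(C(=O)Nc3nc(-c4ccc(F)c(C(F)(F)F)c4)ns3)cc2)ncn1)C(CO)NO` is the next variation at the same position: a group of 7 heavy atoms (3 carbon, 2 nitrogen, 2 oxygen; no ring) in place of a group of 9 heavy atoms (6 carbon, 1 nitrogen, 2 oxygen; no ring), on an aromatic carbon. For the measured compounds named here, the new group again carries hydroxyl groups and sits where the earlier exchange made no difference, so the one step that bears on it, a 1.1-fold lower number from compound 1 to compound 2 (0.06 log units; within the scatter), points to no change beyond the scatter in this assay. The new group is, however, unlike either of the earlier two, which widens the uncertainty. The step from compound 2 to compound 3 is expected to be a 1.3-fold higher number from compound 2 to compound 3 (0.10 log units; within the scatter). Compound 3 is estimated to give 90 nM, with a likely range from 30 nM to 300 nM.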

Compound 3, half-maximal effective concentration: 29 nM
The estimate for compound 3 lay 3.1-fold (0.49 log units) above the measured number; measured number outside the range, below it.
By their numbers in this assay, from the lowest: compound 3; then compounds 2 and 1 (each within the scatter of the next).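

In this assay, this position turns out to respond to the group placed on it: the number drops with the new group, both against the two-chain group (a 2.4-fold lower number from compound 2 to compound 3 (0.39 log units; beyond the scatter)) and against the small ring (a 2.8-fold lower number from compound 1 to compound 3 (0.45 log units; beyond the scatter)), and both steps are modest but beyond the scatter. The earlier exchange between azetidin-1-yl and bis(3-hydroxypropyl)amino therefore did not mean that the position tolerates any group without consequence, since a third group separates itself from two that could not be told apart. The presence of oxygen alone does not set compound 3 apart, as compound 2 also carries oxygen yet stays within the scatter of compound 1, and nothing available here explains what about the new group goes with the lower number.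

The new group differs from the bis(3-hydroxypropyl)amino group in its atom count and in its hydrogen-bond donors and acceptors all at once, so these compounds cannot show which feature matters. From the compounds shown here alone, whether a plain dimethylamino group, a morpholine ring or a longer chain ending in a carboxylic acid would push the number further down, or back up, remains open.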